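The compounds below may be only part of what the source reports. "The series", "measured", "known", "first", "only" and "open" are said of these compounds alone.

Measured in a functional assay on MCF7 cells (Homo sapiens) for cytotoxicity, read by MTT assay, with a stated time of 72 h; a lower number here means a stronger inhibitor, a higher number a weaker inhibitor:
- compound 1 `O=C1c2c[n+]([O-])c3ccccc3c2C(=O)c2c1c1ccccc1n2Cc1cn(C[C@H](O)CO)nn1`: > 1000 nM
- compound 2 `O=C1c2c[n+]([O-])c3ccccc3c2C(=O)c2c1c1ccccc1n2CCN1CCCC1`: 320 nM
- compound 3 `CN1CCN(CCCn2c3c(c4ccccc42)C(=O)c2c[n+]([O-])c4ccccc4c2C3=O)CC1`: 220 nM

Compound 1 stands at a limit of the assay, not at a number: the limit of > 1000 nM in this assay, at which 1 of the 3 values shown sits.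

Compound 4 `O=C1c2c[n+]([O-])c3ccccc3c2C(=O)c2c1c1ccccc1n2Cc1cn([C@H]2C[C@H](O)[C@@H](CO)O2)nn1` differs from compound 1 in one place, with 4-hydroxy-5-(hydroxymethyl)oxolan-2-yl in place of 2,3-dihydroxypropyl on an aromatic nitrogen. Within the data shown here, no measured step makes this exact change. The nearest are an at least 3.1-fold lower number from compound 1 to compound 2 (0.49 log units; beyond the scatter) and an at least 4.5-fold lower number from compound 1 to compound 3 (0.65 log units; beyond the scatter), both modest at the least. Each of them replaces the whole side chain, including the five-membered aromatic ring with 3 nitrogen. Compound 4 keeps that ring, so these steps give no reason to expect it to leave the range of compound 1. The step of a 1.5-fold lower number from compound 2 to compound 3 (0.16 log units; within the scatter) lies within the scatter and concerns other side chains, so it adds little here. The estimated change is a step that the limit leaves unreadable from compound 1 to compound 4, which means no step beyond the scatter is expected in this assay, and no direction is favoured. For compound 4 the estimated value is 1500 nM, with an expected range of 500 nM to 5000 nM.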

Compound 4, half-maximal inhibitory concentration: 530 nM
Beside the measured number, compound 4's estimate is 2.8-fold (0.45 log units) above it; the range from low to high includes it.
By their numbers in this assay, from the lowest: compounds 3, 2 and 4 (each within the scatter of the next, the first and the last beyond it). At a limit, above all of these: compound 1.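

In this assay, compound 4 gives 530 nM, which shows that a side chain keeping the five-membered aromatic ring with 3 nitrogen can give a number rather than a limit. Setting 4-hydroxy-5-(hydroxymethyl)oxolan-2-yl in place of 2,3-dihydroxypropyl on that ring's aromatic nitrogen gives an at least 1.8-fold lower number from compound 1 to compound 4 (0.27 log units; that floor lies within the scatter), so this floor alone does not establish a real change, though the true step may be larger. Compound 1 stands at a limit and not at a number, so only a floor can be read for this step: the limit of > 1000 nM in this assay, at which 1 of the 4 values shown sits.

The compounds shown leave open which part of the entering group matters: the ring oxygen, the non-aromatic ring itself or the extra stereocentres. They also do not tell how a dimethylamino group, a carboxylic acid or a longer chain would read on this aromatic nitrogen.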